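Leaving the limit: compound 3 to compound 4

The source may hold more compounds than are shown below. What is called first, only, known or untested is meant among the compounds shown, and "the series" means these compounds.

Measured in a functional assay on MCF cells (Homo sapiens) for antiproliferative activity, with a stated time of 72 h; a higher number here means a weaker inhibitor, a lower number a stronger inhibitor:
compound 1 `OC[C@H]1O[C@@H](n2cnc3c(NCc4cccc(F)c4)ncnc32)[C@H](O)[C@@H]1O`: 15300 nM
compound 2 `OC[C@H]1O[C@@H](n2cnc3c(NCc4ccc(F)cc4)ncnc32)[C@H](O)[C@@H]1O`: 21000 nM
compound 3 `OC[C@H]1O[C@@H](n2cnc3c(NCc4ccc(Br)cc4)ncnc32)[C@H](O)[C@@H]1O`: > 166000 nM (a limit, not a number)

Compound 3 has only a limit and no number, and it is the weakest of the three. Its place is the limit of > 166000 nM in this assay, at which 1 of the 3 values shown sits. Compound 4 `COc1ccccc1CNc1ncnc2c1ncn2[C@@H]1O[C@H](CO)[C@@H](O)[C@H]1O` is the next structure, and the change is 2-methoxyphenyl in place of 4-bromophenyl on a saturated chain carbon bound to a nitrogen on an aromatic ring.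

Within the data shown here, two measured steps bear on this, both ending at the 4-bromophenyl group: an at least 10-fold higher number from compound 1 to compound 3 (1.03 log units; beyond the scatter) and an at least 7.9-fold higher number from compound 2 to compound 3 (0.89 log units; beyond the scatter). Both lie beyond the scatter. The third step, a 1.4-fold higher number from compound 1 to compound 2 (0.14 log units; within the scatter), lies within it. Among the measured compounds shown here, no measured compound carries 2-methoxyphenyl, so that group's own effect is unknown.

Given an at least 7.9-fold higher number from compound 2 to compound 3 (0.89 log units; beyond the scatter), leaving 4-bromophenyl is expected to give a lower number in this assay, of a size like those two steps reversed, though a second limit remains possible. The expected step is an at least 5.5-fold lower number from compound 3 to compound 4 (0.74 log units; beyond the scatter). Compound 4 is estimated at 30000 nM, with an expected range of 9000 nM to 120000 nM.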

Compound 4, half-maximal inhibitory concentration: > 166000 nM
Compound 4 was reported as a limit; the forecaster's own chance of this, stated with the estimate: 25%; middle value at least 5.5-fold (0.74 log units) away from the limit.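

In this assay, the change to 2-methoxyphenyl on a saturated chain carbon bound to a nitrogen on an aromatic ring gives an at least 7.9-fold higher number from compound 2 to compound 4 (0.89 log units; beyond the scatter) and an at least 10-fold higher number from compound 1 to compound 4 (1.03 log units; beyond the scatter). Compound 3 and compound 4 are both reported only as limits, so the step between them cannot be read. A readable value is thus lost with a group other than 4-bromophenyl, and only the fluorophenyl compounds, compound 1 and compound 2, still carry numbers: the limit of > 166000 nM in this assay, at which 2 of the 4 values shown sit.

From the compounds shown here alone, how far compound 3 and compound 4 lie beyond that limit remains open, and so does any order between them. A 4-methoxyphenyl or 2-fluorophenyl group would help show whether the loss in compound 4 follows the methoxy group or its place on the ring.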